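The compounds below may be only part of what the source reports. "The series", "measured", "known", "first", "only" and "open" are said of these compounds alone.

In a functional assay on MCF7 cells (Homo sapiens) for inhibition, read by resazurin assay, with a stated time of 72 h (a lower number here means a stronger inhibitor, a higher number a weaker inhibitor), compound 1 (`CCOc1ccc(C2C(C3CC3)C(=O)N2c2cc(OC)c(OC)c(OC)c2)cc1`) gives 131 nM and compound 2 (`C=CC1C(=O)N(c2cc(OC)c(OC)c(OC)c2)C1c1ccc(OC)cc1`) gives 17 nM. Compound 2 therefore holds the lower of the two numbers, and its gap to compound 1 lies beyond the scatter. Compound 3 (`C=CC1C(=O)N(c2cc(OC)c(OC)c(OC)c2)C1c1ccc(OCC)cc1`) has not yet been measured. It departs from compound 2 in one place, where methoxy becomes ethoxy and 4-methoxyphenyl becomes 4-ethoxyphenyl: methyl in place of hydrogen on a saturated chain carbon bound to an oxygen on an aromatic ring. A modest rise in this assay is expected, toward a weaker inhibitor, since compound 1 gives 131 nM with a 4-ethoxyphenyl group. For the measured compounds named here, no measured pair shows this change alone, so that guide is weak, and a result within the scatter would not be surprising. The expected size of the change is a 1.8-fold higher number from compound 2 to compound 3 (0.25 log units; within the scatter). For compound 3 the estimated value is 30 nM, with an expected range from 10 nM to 90 nM.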

Compound 3, half-maximal inhibitory concentration: 14 nM
Beside the measured number, compound 3's estimate is 2.1-fold (0.33 log units) above it, within the range that was stated.
By their numbers in this assay, from the lowest: compounds 3 and 2 (each within the scatter of the next); then compound 1.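

In this assay the change from 4-methoxyphenyl to 4-ethoxyphenyl gives a 1.2-fold lower number from compound 2 to compound 3 (0.08 log units; within the scatter) and so shows that methyl in place of hydrogen on this saturated chain carbon leaves the number within the scatter. With the 4-ethoxyphenyl group held constant, vinyl in place of cyclopropyl on a saturated ring carbon gives a 9.4-fold lower number from compound 1 to compound 3 (0.97 log units; beyond the scatter) and so shows that the 4-ethoxyphenyl group does not by itself bring the higher number of compound 1. Nothing available explains either step.

As far as these compounds go, whether a longer chain such as propoxy or butoxy, or an amine at the end of the chain, would also stay within the scatter of compound 3 remains open. Also open, from the compounds shown here alone, is how an ethyl group in place of vinyl on the saturated ring carbon would read.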